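Removing the Benzyl Amide: Expectation for Compound 4

The compounds below may be only part of what the source reports. "The series", "measured", "known", "first", "only" and "open" are said of these compounds alone.

Compound 1 `NNC(=O)Cc1cc(=O)oc2cc(OCc3cccc(Cl)c3)ccc12`: 2500 nM
Compound 2 `CC(C(N)=O)c1cc(=O)oc2cc(OCc3ccccc3)ccc12`: 6260 nM
Compound 3 `O=C(Cc1cc(=O)oc2cc(OCc3cccc(Cl)c3)ccc12)NCc1ccccc1`: a limit of the assay, > 100000 nM

Among the three measured compounds, compound 3 is the one reported only as a limit in an assay (strain Wistar) for inhibition of Amine oxidase [flavin-containing] A (Rattus norvegicus); on this read-out higher numbers stand for weaker inhibition and lower numbers for stronger inhibition (the limit of > 100000 nM in this assay, at which 1 of the 3 values shown sits), so no number is known for it. Among the measured compounds shown here, the single measured step that bears on the change is an at least 40-fold higher number from compound 1 to compound 3 (1.60 log units; beyond the scatter): attaching the benzyl weakened inhibition strongly. Compound 4 `NCc1cc(=O)oc2cc(OCc3cccc(Cl)c3)ccc12` goes further than undoing this: amino in place of benzylcarbamoyl on a saturated chain carbon bound to an aromatic carbon. With the benzyl gone, a small polar end remains, as in compound 1 with 2500 nM and compound 2 with 6260 nM. A return towards such numbers is therefore expected, meaning the step of an at least 16-fold lower number from compound 3 to compound 4 (1.22 log units; beyond the scatter) in this assay. Compound 4 is estimated at 6000 nM, with a range from 800 nM to 60000 nM.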

Compound 4, half-maximal inhibitory concentration: 2000 nM
Compound 4: the middle estimate sits 3.0-fold (0.48 log units) above what was measured, and the stated range covers the measured number.
By their numbers in this assay, from the lowest: compounds 4 and 1 (each within the scatter of the next); then compound 2. At a limit, above all of these: compound 3.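

Compound 3 is a limit, not a number: the limit of > 100000 nM in this assay, at which 1 of the 4 values shown sits. Even so, an at least 50-fold lower number from compound 3 to compound 4 (1.69 log units; beyond the scatter) in this assay shows that the loss seen with benzylcarbamoyl disappears when plain amino sits on this saturated chain carbon bound to an aromatic carbon. With a 1.3-fold lower number from compound 1 to compound 4 (0.10 log units; within the scatter), amino and aminocarbamoyl cannot be told apart here, so the carbonyl of the amide-type link is not needed to keep this level of inhibition. From the compounds shown here alone, how a carboxylic acid, a hydroxyl or a longer chain ending in an amine would fare at this carbon stays open.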